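The source may report more compounds than this note shows. Statements on the series, on what has been measured and on what is new or still open speak of the compounds shown alone.

In a functional assay on HCT-116 cells (Homo sapiens) for inhibition, read by MTT assay, with a stated time of 72 h (a lower number here means a stronger inhibitor of growth, a higher number a weaker inhibitor of growth), three compounds sharing one core have been measured. Compound 1 `CN(C)c1ccc(-c2nc3c(N4CCN(CC(=O)Nc5cccnc5)CC4)c(Br)cnc3[nH]2)cc1` gives 1650 nM, compound 2 `CN(C)c1ccc(-c2nc3c(N4CCN(CC(=O)Nc5ccccc5)CC4)c(Cl)cnc3[nH]2)cc1` gives 2550 nM, and compound 3 `CN(C)c1ccc(-c2nc3c(N4CCN(Cc5ccncc5)CC4)c(Br)cnc3[nH]2)cc1` gives 700 nM. Compound 3 thus holds the lowest number of the three, and its gaps to the other two both lie beyond the scatter.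

Compound 4 `CC(c1ccncc1)N1CCN(c2c(Br)cnc3[nH]c(-c4ccc(N(C)C)cc4)nc23)CC1` departs from compound 3 in one place: methyl in place of hydrogen on a saturated chain carbon bound to an amine nitrogen in a ring and an aromatic carbon. This is methyl in place of hydrogen on a saturated chain carbon bound to an amine nitrogen in a ring and an aromatic carbon, turning (pyridin-4-yl)methyl into 1-(pyridin-4-yl)ethyl.

Among the measured compounds shown here, only one measured step touches this part of the molecule: a 2.4-fold lower number from compound 1 to compound 3 (0.37 log units; beyond the scatter), a modest change that swaps (pyridin-3-yl)carbamoyl for pyridin-4-yl. For the measured compounds named here, that step replaces a much larger group than the new methyl, and no measured compound carries a methyl on this carbon, so it offers only indirect guidance. It suggests a small change at most, with the direction left open by the data. The expected change is a 1.1-fold higher number from compound 3 to compound 4 (0.06 log units; within the scatter), a slightly higher number that is not expected to stand clear of the scatter. For compound 4 the estimated value is 800 nM, with an expected range from 300 nM to 2100 nM.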

Compound 4, concentration for 50% growth inhibition: 900 nM
Compound 4: the middle estimate sits 1.1-fold (0.05 log units) below what was measured, and the stated range covers the measured number.
By their numbers in this assay, from the lowest: compounds 3, 4, 1 and 2 (each within the scatter of the next, the first and the last beyond it).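

In this assay, among the compounds shown here, the step of a 1.3-fold higher number from compound 3 to compound 4 (0.11 log units; within the scatter) is the first reading at this carbon. It shows that methyl can take the place of hydrogen on the saturated chain carbon bound to an amine nitrogen in a ring and an aromatic carbon without a shift that stands clear of the scatter, so this position accepts this small addition in the growth read-out of these cells. The comparison with the amide side chain also changes in kind: the step of a 2.4-fold lower number from compound 1 to compound 3 (0.37 log units; beyond the scatter) lay beyond the scatter, whereas the step of a 1.8-fold lower number from compound 1 to compound 4 (0.26 log units; within the scatter) lies within it, so the separation from ((pyridin-3-yl)carbamoyl)methyl that (pyridin-4-yl)methyl showed is not clearly seen with 1-(pyridin-4-yl)ethyl, even though the two pyridine-bearing groups themselves cannot be told apart here.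

As far as these compounds go, whether an ethyl, a hydroxymethyl or a second methyl on this same carbon would also stay within the scatter remains open. So does whether a methyl on the chain carbon of the amide side chain would read the same way, and nothing at hand gives a cause for any of these numbers.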